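Morpholine in Place of Butyl on a Nitro and Amino Thiourea

The source may hold more compounds than are shown below. What is called first, only, known or untested is meant among the compounds shown, and "the series" means these compounds.

Measured compounds and their values:
compound 1, `CCCCC(=O)NC(=S)Nc1nc2cc([N+](=O)[O-])ccc2s1`: > 100000 nM
compound 2, `O=C(NC(=S)Nc1nc2cc([N+](=O)[O-])ccc2s1)N1CCOCC1`: 31000 nM
compound 3, `CCCCC(=O)NC(=S)Nc1nc2cc(N)ccc2s1`: 44700 nM

All three were tested in a functional assay on MCF7 cells (Homo sapiens) for cytotoxicity, read by MTT assay, with a stated time of 24 h; a lower number here means a stronger inhibitor, a higher number a weaker inhibitor. The value of compound 1 is a limit of the assay, not a number. Replacing the butyl with a morpholin-4-yl on the carbonyl carbon, (morpholin-4-yl in place of butyl on a carbonyl carbon), produced an at least 3.2-fold lower number from compound 1 to compound 2 (0.50 log units; beyond the scatter). Compound 3 has a different core from compound 1: amino in place of nitro on an aromatic carbon, and this change produced an at least 2.2-fold lower number from compound 1 to compound 3 (0.34 log units; beyond the scatter). The values of compound 2 and compound 3 lie within the usual scatter of each other, so nothing can be said about which is stronger.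

Compound 4, `Nc1ccc2sc(NC(=S)NC(=O)N3CCOCC3)nc2c1`, has not been measured. It stands to compound 3 exactly as compound 2 stands to compound 1: morpholin-4-yl in place of butyl on a carbonyl carbon, the same change at the same place. The step from compound 3 to compound 4 is expected to be a 3.2-fold lower number from compound 3 to compound 4 (0.50 log units; beyond the scatter), similar to the earlier one, because an at least 3.2-fold lower number from compound 1 to compound 2 (0.50 log units; beyond the scatter) went beyond the scatter; the earlier step is known only as a minimum, so the new one could be larger. Compound 4 is therefore expected to give about 14000 nM in this assay, with a likely range from 5000 nM to 40000 nM.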

Compound 4, half-maximal inhibitory concentration: 26400 nM
Beside the measured number, compound 4's estimate is 1.9-fold (0.28 log units) below it, within the range that was stated.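

With amino on the aromatic carbon, putting morpholin-4-yl in place of butyl on the carbonyl carbon gives, in this assay, a 1.7-fold lower number from compound 3 to compound 4 (0.23 log units; within the scatter), so this pair cannot be told apart, and the step from the nitro series does not reappear beyond the scatter. Set side by side, the two steps for this change read as follows: the same change on two cores in this assay, an at least 3.2-fold lower number (0.50 log units; beyond the scatter) from compound 1 to compound 2 and a 1.7-fold lower number (0.23 log units; within the scatter) from compound 3 to compound 4; the limit leaves it open whether they differ. The exchange of nitro for amino behaves in the same way, with morpholin-4-yl in place this time giving a 1.2-fold lower number from compound 2 to compound 4 (0.07 log units; within the scatter), and its two steps compare thus: the same change on two cores in this assay, an at least 2.2-fold lower number (0.34 log units; beyond the scatter) from compound 1 to compound 3 and a 1.2-fold lower number (0.07 log units; within the scatter) from compound 2 to compound 4; the limit leaves it open whether they differ.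

So neither change is shown to carry its effect from one core to the other, yet neither is shown to lose it, since each comparison rests on compound 1, whose value is a limit of the assay and not a number.

What the compounds shown leave open is whether any other group on the carbonyl carbon, such as piperidin-1-yl or a longer chain, would separate itself from butyl and morpholin-4-yl on either core. Also open, going by these compounds, is how a methoxy group or a chlorine atom in place of nitro or amino on the aromatic carbon would read in this assay.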